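The compounds below may be only part of what the source reports. "The series", "measured", "known", "first", "only" and "open" are said of these compounds alone.

In an ADME assay on HEK293 cells (Homo sapiens) for cytotoxicity, with a stated time of 72 h (a lower number here means that less compound is needed, a higher number that more compound is needed for the effect), three compounds have been measured so far. Compound 1 (`C=C[C@@](C)(/C=C/c1ccc(O)c(C=O)c1)CCC=C(C)C`) gives > 36600 nM as a limit of the assay and not a number. Compound 2 (`CC(C)=CCC[C@](C)(/C=C/c1ccc(O)cc1)/C=C/c1cccc(F)c1`) gives > 36600 nM as a limit too. Compound 3 (`C=C[C@@](C)(/C=C/c1ccc(Nc2ccc(OC(F)(F)F)cc2)cc1)CCC=C(C)C`) gives > 36600 nM as a limit as well. Compound 3 therefore stands with the other two at the limit of > 36600 nM in this assay, at which 3 of the 3 values shown sit, and has no exact number. Compound 4 (`C=C[C@@](C)(/C=C/c1ccc(Nc2ccc(Cl)cc2)cc1)CCC=C(C)C`) has chloro in place of trifluoromethoxy on an aromatic carbon, para to a large group (chloro in place of trifluoromethoxy on an aromatic carbon). No measured step sizes this swap, so no shift beyond the scatter is expected in this assay and the expected change is a number no higher from compound 3 to compound 4 (the limit leaves the size open) in either direction. For compound 4 the estimated value is 36600 nM with an expected range from 15000 nM to 60000 nM as the likely span.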

Compound 4, half-maximal effective concentration: > 36600 nM
Compound 4: no number, only a limit; the forecaster's own chance of this, stated with the estimate: 75%; the middle value lies on the limit itself.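

No step can be read from compound 3 to compound 4, since both give only a limit of the assay and not a number: the limit of > 36600 nM in this assay, at which 4 of the 4 values shown sit.

The compounds shown leave open, in this assay, how far each lies from that limit and which change would give an exact number.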